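Adding a methoxy group to compound 2

The compounds below may be only part of what the source reports. "The series", "measured", "known", "first", "only" and "open" are said of these compounds alone.

- compound 1 `COc1ccccc1/C=C1\CCC/C(=C\c2ccc(OC)c(OC)c2)C1=O`: 7800 nM
- compound 2 `COc1ccc(/C=C2\CCC/C(=C\c3ccc(OC)c(OC)c3)C2=O)cc1`: 6600 nM

Both values come from a functional assay on SW-620 cells (Homo sapiens) for cytotoxicity, read by MTT assay, with a stated time of 72 h; on this read-out higher numbers stand for weaker inhibition and lower numbers for stronger inhibition. Among the measured compounds shown here, compound 2 stands level with the only other measured compound, within the scatter. Compound 3 `COc1ccc(/C=C2\CCC/C(=C\c3ccc(OC)c(OC)c3)C2=O)c(OC)c1` differs from compound 2 by methoxy in place of hydrogen on an aromatic carbon, ortho to a large group and meta to a methoxy group. For the measured compounds named here, one measured step bears on this, and it only relocates a methoxy group: a 1.2-fold lower number from compound 1 to compound 2 (0.07 log units; within the scatter). No shift beyond the scatter is therefore expected in this assay. The estimated step is a 1.1-fold lower number from compound 2 to compound 3 (0.04 log units; within the scatter). Compound 3 is expected at 6000 nM, with an estimated range of 2500 nM to 14000 nM.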

Compound 3, half-maximal inhibitory concentration: > 20000 nM
Compound 3: only a limit was reported; the forecaster's own chance of this, stated with the estimate: 2%; at least 3.3-fold (0.52 log units) between middle value and limit.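

Compound 3 gives only a limit of the assay in this assay, not a number: the limit of > 20000 nM in this assay, at which 1 of the 3 values shown sits.

Read with that limit, the new steps are an at least 3.0-fold higher number from compound 2 to compound 3 (0.48 log units; beyond the scatter) and an at least 2.5-fold higher number from compound 1 to compound 3 (0.40 log units; beyond the scatter), whereas relocating a methoxy group gave only a 1.2-fold lower number from compound 1 to compound 2 (0.07 log units; within the scatter). Added methoxy on this aromatic carbon, ortho to a large group and meta to a methoxy group, therefore weakens the read-out, which relocation alone did not show.

Going by these compounds, the true size of the loss stays open behind the limit. On these data alone, whether fluoro or hydroxy on this carbon would act like methoxy also stays open.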